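Chain carbon on the shared core: compound 2 to compound 3

The source may report more compounds than this note shows. Statements on the series, on what has been measured and on what is new or still open speak of the compounds shown alone.

Measured so far:
compound 1 `Nc1nc(O)c2c(n1)n(C1OC(CO)[C@@H](O)[C@H]1O)c(=O)n2CC(O)CSc1ccccc1`: 12%
compound 2 `Nc1nc(O)c2c(n1)n(C1OC(CO)[C@@H](O)[C@H]1O)c(=O)n2Cc1ccc(Cl)cc1`: 15%

In a functional assay on the whole organism (B cells) with Mus musculus as the target (a higher number here means a larger maximal response, a lower number a smaller maximal response), compound 1 gives 12%. In this assay, among the compounds with values here, compound 2 gives 15% and so stands at the upper of the two measured numbers, though the gap to compound 1 is within the scatter; the one measured step, a number 3 percentage points higher from compound 1 to compound 2 (within the scatter), is the only guide available at this place.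

Compound 3 `Nc1nc(O)c2c(n1)n(C1OC(CO)[C@@H](O)[C@H]1O)c(=O)n2CCN1CCCCC1` is not yet measured. It differs from compound 2 by (piperidin-1-yl)methyl in place of 4-chlorophenyl on a saturated chain carbon bound to an aromatic nitrogen. The step from compound 1 to compound 2 changed the group at the same place and moved the maximal response by no more than the scatter. On that basis the step is expected to be no change at the digits printed from compound 2 to compound 3 (within the scatter), no change beyond the scatter in either direction. Compound 3 is estimated at 15% in this assay. Compound 3 is expected to fall between 5% and 30%.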

Compound 3, largest response reached (reported as maximal response), in percent of the reference or control that the assay uses: 0%
Compound 3: middle estimate off by 15 percentage points, on the high side; measured number outside the range, below it.
By their numbers in this assay, from the lowest: compound 3; then compounds 1 and 2 (each within the scatter of the next).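

In this assay, the place on a saturated chain carbon bound to an aromatic nitrogen no longer looks indifferent to exchange: the result is a number 15 percentage points lower from compound 2 to compound 3 (beyond the scatter) and a number 12 percentage points lower from compound 1 to compound 3 (beyond the scatter), whereas the earlier exchange here gave a number 3 percentage points higher from compound 1 to compound 2 (within the scatter). The leaving 4-chlorophenyl and the entering (piperidin-1-yl)methyl both count 7 heavy atoms, so heavy-atom count alone does not separate compound 2 from compound 3; they differ in one six-membered aromatic ring of carbon only against one six-membered non-aromatic ring with 1 hetero atom. No measurement at hand explains this fall.

On these data alone, what remains open is whether the fall belongs to the piperidin-1-yl group itself or to the ring nitrogen. Compounds carrying 2-cyclohexylethyl, 2-(morpholin-4-yl)ethyl or 2-(dimethylamino)ethyl at this place would separate these readings.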